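Lengthening the methoxy group on compound 2 to allyloxy

The source may hold more compounds than are shown below. What is called first, only, known or untested is meant among the compounds shown, and "the series" means these compounds.

Of the compounds shown here, two have numbers so far. Compound 1 `COc1nc(-c2cccnc2)cc(-c2ccc(F)cc2)c1C#N` gives 213 nM in an assay on isolated protein for inhibition of sulfide:quinone oxidoreductase, mitochondrial (Homo sapiens); a lower number here means a stronger inhibitor, a higher number a weaker inhibitor. Within the data shown here, compound 2 `COc1nc(-c2ccccn2)cc(-c2ccc(F)cc2)c1C#N` gives 14 nM in this assay, the lowest of the two numbers; the single measured step, a 15-fold lower number from compound 1 to compound 2 (1.18 log units; beyond the scatter), comes from exchanging the pyridin-3-yl group for a pyridin-2-yl group. Compound 3 `C=CCOc1nc(-c2ccccn2)cc(-c2ccc(F)cc2)c1C#N` differs from compound 2 in a different place: vinyl in place of hydrogen on a saturated chain carbon bound to an oxygen on an aromatic ring, so that the methoxy group becomes an allyloxy group. Among the measured compounds shown here, no measured step touches this part of the shared core, and the numbers therefore give no direction for the change. The expectation is a step of about the size of ordinary repeat scatter, a 1.4-fold higher number from compound 2 to compound 3 (0.15 log units; within the scatter), meaning no change that could be told apart from remeasurement. Compound 3 is thus estimated to give 20 nM in this assay, within a range from 5 nM to 80 nM.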

Compound 3, half-maximal inhibitory concentration: 5.5 nM
Compound 3: the middle estimate sits 3.6-fold (0.56 log units) above what was measured; measured number inside the range.
By their numbers in this assay, from the lowest: compound 3; then compound 2; then compound 1.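

Going from methoxy to allyloxy gives a 2.5-fold lower number from compound 2 to compound 3 (0.41 log units; beyond the scatter) in this assay, so the group on this oxygen, which no earlier step had touched, also changes the number. The earlier step showed only the effect of exchanging one pyridine attachment for another, whereas this one shows that a vinyl group can be added here without any loss of inhibition, and with a modest gain. Nothing available explains why this change lowers the number.

On these data alone, it remains open whether the double bond matters or the added length alone is enough, and a saturated propoxy group would tell these two apart. Also open, as far as these compounds go, are how a benzyloxy group or a longer chain carrying an amine would fare, and whether allyloxy gives a similar gain alongside the pyridin-3-yl group of compound 1.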